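Methyl for cyclopropyl at the low end of stability

A few compounds are considered here, and "the series" means these few. Any claim that something is new, unique, unknown or untested is made for them only; others in the source may bear on it.

Of the compounds shown here, three have been measured in an ADME assay on microsomes from liver (Homo sapiens) for metabolic stability, read by LC-MS, with a stated time of 10 min (a higher number here means that more of the compound is left, a lower number that less of the compound is left), so far. Compound 2 `CN(C[C@H]1Cc2c(cccc2N2CCN(C3CC3)CC2)CN1)[C@H]1CCCc2cccnc21` stands lowest of the three, with 15.5% left. Compound 3 `FC1(F)CCC(CN(C[C@H]2Cc3c(cccc3N3CCNCC3)CN2)[C@H]2CCCc3cccnc32)CC1` is nearest to it with 68.6% left, and compound 1 `CN(C[C@@H]1Cc2c(cccc2N2CCNCC2)CN1)[C@H]1CCCc2cccnc21` is furthest with 94.2% left. Both gaps lie beyond the usual scatter. Among the measured compounds shown here, no two measured compounds differ in one place only, so these gaps give no clean step for any single change.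

The next compound is compound 4 `CN1CCN(c2cccc3c2C[C@H](CN(C)[C@H]2CCCc4cccnc42)NC3)CC1`, which differs from compound 2 at one group (methyl in place of cyclopropyl on an amine nitrogen in a ring). The change is methyl in place of cyclopropyl on an amine nitrogen in a ring, or 4-cyclopropylpiperazin-1-yl to 4-methylpiperazin-1-yl when cut one bond further out.

For the measured compounds named here, with no measured step to draw on, the only guide is the spread of values. Compound 2 has 15.5% left in this assay and sits far under the other two, so a rise looks more likely than a fall, although a result within the scatter remains possible. The expected change is a number 19.5 percentage points higher from compound 2 to compound 4 (beyond the scatter) as a moderate rise with wide uncertainty. In this assay the estimated value for compound 4 is 35% with an expected range from 14% to 65% of compound left.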

Compound 4, percent of the compound remaining: 75.8%
Compound 4: the middle estimate sits 40.8 percentage points below what was measured, and the stated range ends below it.
By their numbers in this assay, from the lowest: compound 2; then compounds 3 and 4 (each within the scatter of the next); then compound 1.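

Methyl in place of cyclopropyl on an amine nitrogen in a ring gives a number 60.3 percentage points higher from compound 2 to compound 4 (beyond the scatter) in this assay, the first step in the series that can be read for a single change. Since the two structures differ only in this group, the whole gap within this pair goes with leaving cyclopropyl for methyl on the 4-substituted piperazine, which takes compound 2 from 15.5% to compound 4 at 75.8%, so this position has a strong bearing on the read-out with the rest of the structure held constant. No measurement shown here explains why the exchange of these two groups separates the pair so widely.

Going by these compounds, the step rests on a single pair, so it remains open whether it carries over to compounds with other changes elsewhere in the structure, such as the different group on the exocyclic amine of compound 3. Ethyl, isopropyl or acetyl on the same ring nitrogen would show whether the low value goes with cyclopropyl specifically or with any group other than methyl at this place.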